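Replacing the dimethylamino group of compound 2

The source may hold more compounds than are shown below. What is called first, only, known or untested is meant among the compounds shown, and "the series" means these compounds.

Compound 1 `CC(=O)OC/C1=C/C[C@](C)(CCC=C(C)C)/C=C/[C@@H](OC(=O)C=C(C)C)[C@](C)(OC(C)=O)/C=C/C1=O`: 3480 nM
Compound 2 `CC(C)=CCC[C@]1(C)/C=C/[C@@H](OC(=O)C=C(C)C)[C@](C)(O)/C=C/C(=O)/C(CN(C)C)=C\C1`: 140 nM
Compound 3 `CC(C)=CCC[C@]1(C)/C=C/[C@@H](OC(=O)C=C(C)C)[C@](C)(O)/C=C/C(=O)/C(C[Si](c2ccccc2)(c2ccccc2)C(C)(C)C)=C\C1`: 14400 nM

These values come from a functional assay on HL-60 cells (Homo sapiens) for antiproliferative activity, read by MTT assay, with a stated time of 48 h (on this read-out higher numbers stand for weaker inhibition and lower numbers for stronger inhibition), and share a common core. Compound 2 gives 140 nM as the lowest of the three numbers, which makes it the strongest inhibitor here. Compound 1 and compound 3 both stand above it by more than the usual scatter of repeat measurements.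

Compound 4 `CC(C)=CCC[C@]1(C)/C=C/[C@@H](OC(=O)C=C(C)C)[C@](C)(O)/C=C/C(=O)/C(COC(=O)c2ccc([N+](=O)[O-])cc2)=C\C1` has not yet been measured. In it, ((4-nitrophenyl)carbonyl)oxy sits in place of dimethylamino on a saturated chain carbon bound to a double-bonded ring carbon, a change counted as ((4-nitrophenyl)carbonyl)oxy in place of dimethylamino on a saturated chain carbon bound to a double-bonded ring carbon here. Among the measured compounds, only compound 2 carries dimethylamino. Within the data shown here, compound 1 gives 3480 nM with an ester at that same place, though it also differs elsewhere, so no measured pair isolates this change.

In this assay a rise beyond the scatter, toward weaker inhibition, is expected as an 18-fold higher number from compound 2 to compound 4 (1.25 log units; beyond the scatter) on this estimate. For compound 4 the estimate is 2500 nM with a range from 600 nM to 10000 nM as the expected spread.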

Compound 4, half-maximal inhibitory concentration: 830 nM
Compound 4: the middle estimate sits 3.0-fold (0.48 log units) above what was measured; the measured number falls inside the stated range.
By their numbers in this assay, from the lowest: compound 2; then compound 4; then compound 1; then compound 3.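

Here, for the first time, a change at this place can be read on its own: in this assay, ((4-nitrophenyl)carbonyl)oxy in place of dimethylamino on a saturated chain carbon bound to a double-bonded ring carbon gives a 5.9-fold higher number from compound 2 to compound 4 (0.77 log units; beyond the scatter). The step favours dimethylamino, yet compound 4 still gives 830 nM, so in this pair activity does not depend on keeping dimethylamino, and the place accepts a larger group carrying an aromatic ring. No supporting measurement bears on what lies behind this step.

As far as these compounds go, whether another amine, such as pyrrolidine or morpholine, would match dimethylamino at this place remains open. A benzoyloxy group without the nitro group would show whether the nitro group contributes to the value of compound 4 830 nM.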